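The compounds below may be only part of what the source reports. "The series", "measured", "known", "first", "only" and "open" are said of these compounds alone.

Measured compounds:
compound 1 `C/C(CN(C[C@H]1Cc2ccccc2CN1)[C@H]1CCCc2cccnc21)=C(/F)CN`, 1800 nM
compound 2 `NC[C@H]1CC[C@H](CN(C[C@H]2Cc3ccccc3CN2)[C@H]2CCCc3cccnc32)CC1`, 340 nM

Among these, compound 1 stands at the highest number, meaning the weakest inhibition in a functional assay on CCRF-CEM cells for antagonist activity at C-X-C chemokine receptor type 4 (Homo sapiens), read by calcium flux, with stated times of 25 min and 90 s; on this read-out higher numbers stand for weaker inhibition and lower numbers for stronger inhibition. Compound 3 `N[C@H]1CC[C@H](N(C[C@H]2Cc3ccccc3CN2)[C@H]2CCCc3cccnc32)CC1` differs from compound 1 by 4-aminocyclohexyl in place of 4-amino-3-fluoro-2-methylbut-2-en-1-yl on an amine nitrogen. Among the compounds with values here, the only step that bears on this change is a 5.3-fold lower number from compound 1 to compound 2 (0.72 log units; beyond the scatter), where a cyclohexyl ring bearing an amine also replaced the fluorinated alkene chain. Because of a 5.3-fold lower number from compound 1 to compound 2 (0.72 log units; beyond the scatter) a step in the same direction is expected for compound 3, though with less certainty since its entering group is not the same as in compound 2; the expected step is a 3.3-fold lower number from compound 1 to compound 3 (0.51 log units; beyond the scatter). Compound 3 is therefore estimated at 550 nM, within 150 nM to 2000 nM.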

Compound 3, half-maximal inhibitory concentration: 34 nM
The estimate for compound 3 lay 16-fold (1.21 log units) above the measured number, outside the stated range (below it).
By their numbers in this assay, from the lowest: compound 3; then compound 2; then compound 1.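

On this amine nitrogen, 4-aminocyclohexyl in place of the fluorinated chain gives a 53-fold lower number from compound 1 to compound 3 (1.72 log units; beyond the scatter) in this assay, so a ring of this kind can do far more than the first step suggested. The ring alone does not settle the outcome: replacing (4-(aminomethyl)cyclohexyl)methyl with 4-aminocyclohexyl gives a 10-fold lower number from compound 2 to compound 3 (1.00 log units; beyond the scatter), although both groups contain a cyclohexyl ring and an amine. Nothing shown explains either step.

From the compounds shown here alone, the two carbons lost between compound 2 and compound 3 changed together, so their separate contributions remain unknown. A 4-(aminomethyl)cyclohexyl group directly on the nitrogen would address this, while a 4-hydroxycyclohexyl group would test the need for the amine.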